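The compounds below may be only part of what the source reports. "The series", "measured", "known", "first", "only" and "open" are said of these compounds alone.

In an assay on cells for inhibition of Amine oxidase [flavin-containing] B (Homo sapiens), read by fluorescence, with a stated time of 30 min (a higher number here means a weaker inhibitor, a lower number a stronger inhibitor), compound 2, `CN(C)c1ccc(/C=C/C(=O)c2ccc(OC(=O)N3CCCC3)cc2O)cc1`, gives 290 nM. This is the lowest of the two numbers recorded so far; the nearest is compound 1, `CCN(CC)C(=O)Oc1ccc(C(=O)/C=C/c2ccc(N(C)C)cc2)c(O)c1`, which in this assay gives 3500 nM. Among the compounds with values here, the one step measured so far, a 12-fold lower number from compound 1 to compound 2 (1.08 log units; beyond the scatter), concerns the carbamate end of the molecule and not the aromatic amine. Compound 3, `CCN(CC)c1ccc(/C=C/C(=O)c2ccc(OC(=O)N3CCCC3)cc2O)cc1`, differs from compound 2 at that other end: diethylamino in place of dimethylamino on an aromatic carbon. Within the data shown here, no measured step touches this position, so there is nothing to point to a large change in either direction, and the expectation for compound 3 is a step within the scatter, a 1.2-fold higher number from compound 2 to compound 3 (0.08 log units; within the scatter). The estimate for compound 3 in this assay is therefore 350 nM, with a range from 120 nM to 1000 nM.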

Compound 3, half-maximal inhibitory concentration: 6700 nM
The estimate for compound 3 lay 19-fold (1.28 log units) below the measured number; the measured number lies above the stated range.
By their numbers in this assay, from the lowest: compound 2; then compounds 1 and 3 (each within the scatter of the next).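

At this position the aromatic amine is not a neutral site: in this assay diethylamino in place of dimethylamino on an aromatic carbon gives a 23-fold higher number from compound 2 to compound 3 (1.36 log units; beyond the scatter) and so moves the number as strongly as a change at the carbamate end can, as seen in a 12-fold lower number from compound 1 to compound 2 (1.08 log units; beyond the scatter) on the carbonyl carbon. The change stays small in kind, since both groups are open-chain amines with no ring, no net charge and the same counts of hydrogen-bond donors and acceptors, yet compound 2 with dimethylamino is clearly favoured over compound 3 here. Nothing measured here explains why this added carbon costs so much.

The compounds shown leave open whether a shorter group such as methylamino or a plain amine would lower the number further, and how a ring amine such as pyrrolidin-1-yl or morpholin-4-yl would behave at this position. They also leave open whether the step from dimethylamino to diethylamino keeps its size when the carbamate end carries diethylamino.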